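Swapping the Aryl Group on a Fused Bicyclic Core

The source may report more compounds than this note shows. Statements on the series, on what has been measured and on what is new or still open speak of the compounds shown alone.

Measured so far:
- Compound 1, `CCCCN(CC)c1cc(C)nc2c1NC(=O)CN2c1ccc(Cl)cc1Br`: "not determined" (no result reported) in an assay on HEK-293T cells for displacement of a labelled ligand from corticotropin-releasing factor receptor 2 (Homo sapiens), read by scintillation counting, with a stated time of 2 h, tested at 1 uM; a higher number here means more inhibition at the concentration tested (going by the name of the read-out), a lower number less inhibition
- Compound 2, `CCCCN(CC)c1cc(C)nc2c1NC(=O)CN2c1ccc(OC)cc1C`: -2.3%

Within the data shown here, compound 2 stands alone as the only compound with a number in this assay, and that number is essentially nothing: it shows no displacement of the labelled ligand at the concentration tested. Among the measured compounds shown here, compound 1 carries no result, so there is no step between measured compounds to lean on.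

Compound 3, `CCCCN(CC)c1cc(C)nc2c1NC(=O)CN2c1ccc(Cl)cc1Cl`, is the untested member. It differs from compound 2 in one place: 2,4-dichlorophenyl in place of 4-methoxy-2-methylphenyl on a nitrogen on an aromatic ring in a ring.

For the measured compounds named here, with no measured step to guide the size of the change, the expectation rests only on the fact that compound 2 sits at the floor. Compound 3 is expected to show a number 10.3 percentage points higher from compound 2 to compound 3 (beyond the scatter), an upward move that may well stay within the scatter. The estimated value for compound 3 in this assay is 8%, with a range from -10% to 35%.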

Compound 3, a percentage reported as inhibition, at one concentration (the size of the read-out at that concentration, not a potency): 0.9%
The estimate for compound 3 lay 7.1 percentage points above the measured number; the measured number falls inside the stated range.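

Setting 2,4-dichlorophenyl in place of 4-methoxy-2-methylphenyl gives, in this assay, a number 3.2 percentage points higher from compound 2 to compound 3 (within the scatter). A single number could not show this: both compounds now leave the labelled ligand in place at the concentration tested, so this change on the nitrogen has no readable effect on the result. Nothing measured here offers an explanation for this outcome.

Both groups shown are substituted phenyl rings, so it remains open whether any other group on this nitrogen, such as a pyridine ring, a phenyl ring carrying a carboxylic acid, or a plain butyl chain, would displace the labelled ligand. Compound 1 gives "not determined" (no result reported), so its bromine-bearing ring adds nothing to the comparison.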